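The compounds below may be only part of what the source reports. "The series", "measured", "known", "first", "only" and "open" are said of these compounds alone.

Values in a functional assay on thoracic aorta (Rattus norvegicus, strain Wistar), with a stated time of 15 min; on this read-out lower numbers stand for an effect already at smaller amounts and higher numbers for an effect only at larger amounts of compound:

Compound 1 `Cc1ccc(S(=O)(=O)NC(=O)NC(C)c2ccccc2OCc2ccccc2)cc1`: > 200000 nM
Compound 2 `CC(NC(=O)N(C)S(=O)(=O)c1ccc(Cl)cc1)c1ccccc1OCc1ccccc1`: 38400 nM
Compound 3 `Cc1ccc(S(=O)(=O)N(C)C(=O)NC(C)c2ccccc2OCc2ccccc2)cc1`: not yet measured

Within the data shown here, compound 2 stands at 38400 nM and is the only compound with an actual number in this assay so far. For compound 1, the entry > 200000 nM is a limit of the assay and not a number.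

Compound 3 differs from compound 2 in one place: methyl in place of chloro on an aromatic carbon. This puts methyl in place of chloro on an aromatic carbon, para to a large group, so that 4-chlorophenyl becomes 4-methylphenyl. Among the measured compounds shown here, no measured pair of compounds differing in a single place is available, so the data give no direct guide to the size of this change.

A small shift in this assay is therefore expected, perhaps none beyond the scatter, with a slight lean toward larger amounts. The expected step is a 1.4-fold higher number from compound 2 to compound 3 (0.16 log units; within the scatter). For compound 3 the estimated value is 55000 nM, with an expected range of 20000 nM to 150000 nM.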

Compound 3, half-maximal effective concentration: 31000 nM
For compound 3 the middle estimate is 1.8-fold (0.25 log units) above the measured one; measured number inside the range.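

In this assay, among these compounds, this is the first direct reading at the aromatic position: going from 4-chlorophenyl to 4-methylphenyl, para to a large group, gives a 1.2-fold lower number from compound 2 to compound 3 (0.09 log units; within the scatter), so in this pair the exchange of chloro for methyl leaves no shift that can be told from the scatter. The result also opens a second comparison, in which methyl in place of hydrogen on an amide-type nitrogen gives an at least 6.4-fold lower number from compound 1 to compound 3 (0.80 log units; beyond the scatter), so among these three compounds the only step beyond the scatter lies at that nitrogen and not on the aromatic ring. Compound 1 stands at a limit of the assay and not at a number, so this step has a lower bound but no known full size: the limit of > 200000 nM in this assay, at which 1 of the 3 values shown sits.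

The compounds shown leave open whether a group of another kind at the same aromatic position, such as an amine or a carboxylic acid, would also stay within the scatter of compound 2. They also leave open whether a longer chain such as ethyl or propyl on the amide-type nitrogen would give a step like the one seen with methyl.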